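The source may report more compounds than this note shows. Statements on the series, on what has been measured and on what is new or still open speak of the compounds shown alone.

Compound 1 `O=C1CC(c2nc(-c3ccccc3)no2)CN1c1ccccc1`: 350 nM
Compound 2 `O=C1CC(c2nc(-c3ccccn3)no2)CN1c1ccc(F)cc1`: > 10000 nM

In an in vitro functional assay on HEK293-A cells for positive allosteric modulation of metabotropic glutamate receptor 5 (Homo sapiens), read by FLIPR and calcium flux (a higher number here means that more compound is needed for the effect, a lower number that less compound is needed), compound 1 gives 350 nM. For compound 2 the result is only a limit of the assay, > 10000 nM, which is the limit of > 10000 nM in this assay, at which 1 of the 2 values shown sits. Compound 3 `O=C1CC(c2nc(-c3ccccc3)no2)CN1c1ccc(F)cc1` has not yet been measured. It differs from compound 2 by phenyl in place of pyridin-2-yl on an aromatic carbon. Compound 1 carries that same phenyl and gives 350 nM. The expected step of an at least 22-fold lower number from compound 2 to compound 3 (1.34 log units; beyond the scatter) therefore points toward less compound being needed. Compound 3 is estimated at 450 nM, with a range from 150 nM to 1500 nM.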

Compound 3, half-maximal effective concentration: 58 nM
For compound 3 the middle estimate is 7.8-fold (0.89 log units) above the measured one; measured number below the stated range.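

In this assay, phenyl in place of pyridin-2-yl, on the aromatic carbon between two ring nitrogen atoms, gives an at least 170-fold lower number from compound 2 to compound 3 (2.23 log units; beyond the scatter), so with the fluoro present a single ring nitrogen in this group separates a clear effect from none detected. Compound 2 gives only a limit of the assay, not a number: the limit of > 10000 nM in this assay, at which 1 of the 3 values shown sits. With phenyl kept, fluoro in place of hydrogen gives a 6.0-fold lower number from compound 1 to compound 3 (0.78 log units; beyond the scatter), a smaller change than the ring swap.

The compounds shown leave open how a pyridin-3-yl group would fare at this place. They also leave open whether a chloro group would match the fluoro.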